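Aryl swap on the succinamide series of compound 1

The source may hold more compounds than are shown below. What is called first, only, known or untested is meant among the compounds shown, and "the series" means these compounds.

Compound 1 `O=C(O)CCC(=O)N(C1CC1)[C@H]1c2ccccc2N(C(=O)c2cccc(OC(F)(F)F)c2)[C@H]2CC[C@H]21` is measured in a functional assay on cells for antagonist activity at prostaglandin D2 receptor 2 (Homo sapiens), read by chemiluminescence and beta-arrestin recruitment, with stated times of 30 min and 60 min (on this read-out lower numbers stand for stronger inhibition and higher numbers for weaker inhibition), where compound 1 gives 43 nM. Among the three numbers known, compound 1 stands highest: compound 3 `O=C(O)COC(=O)N(C1CC1)[C@H]1c2ccccc2N(C(=O)c2ccc(OC(F)(F)F)cc2)[C@H]2CC[C@H]21` gives 1.4 nM in this assay, and compound 2 `O=C(O)COC(=O)N(C1CC1)[C@H]1c2ccccc2N(C(=O)c2cccc(F)c2)[C@H]2CC[C@H]21` gives 1.1 nM, both well beyond the scatter below compound 1. Compounds 2 and 3 share a linker that compound 1 does not, so their gap to compound 1 is not a matter of the aryl group alone.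

Compound 4 `O=C(O)CCC(=O)N(C1CC1)[C@H]1c2ccccc2N(C(=O)c2ccc(F)cc2)[C@H]2CC[C@H]21` differs from compound 1 in one place (4-fluorophenyl in place of 3-(trifluoromethoxy)phenyl on a carbonyl carbon). For the measured compounds named here, the only measured step that bears on this kind of change is the one from compound 2 to compound 3, where a 4-(trifluoromethoxy)phenyl replaced a 3-fluorophenyl on the same carbonyl carbon and gave a 1.3-fold higher number from compound 2 to compound 3 (0.10 log units; within the scatter). That step carries both the change of pattern and the change of substituent across the pair and stayed within the scatter, so the expectation for compound 4 in this assay is a step of roughly a 1.1-fold lower number from compound 1 to compound 4 (0.03 log units; within the scatter), with no clear direction beyond the scatter.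

Compound 4 is therefore estimated at 40 nM in this assay, within a range from 14 nM to 120 nM.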

Compound 4, half-maximal inhibitory concentration: 12 nM
The estimate for compound 4 lay 3.3-fold (0.52 log units) above the measured number; measured number outside the range, below it.
By their numbers in this assay, from the lowest: compounds 2 and 3 (each within the scatter of the next); then compound 4; then compound 1.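

In this assay, the aryl swap on the carbonyl carbon attached to the amide-type nitrogen in a ring gives a 3.6-fold lower number from compound 1 to compound 4 (0.55 log units; beyond the scatter) and so shows that, with the succinamide linker, this position responds to the aryl group by a modest step beyond the scatter. For the compounds shown here, the only earlier step at this carbon, between compound 2 and compound 3 on a different linker, stayed within the scatter, so a change here need not read the same on both linkers, although the two pairs also carry different aryl groups. Nothing given here explains the step from 3-(trifluoromethoxy)phenyl, with 11 heavy atoms, to 4-fluorophenyl, with 7.

Compound 4 changes the substituent and its printed place on the phenyl together, so the compounds shown leave open which of the two matters; a 3-fluorophenyl or a 4-(trifluoromethoxy)phenyl on the succinamide linker would separate them. Also open, as far as these compounds go, is how far the trend runs on this linker, for instance with an unsubstituted phenyl or a 4-chlorophenyl on the same carbonyl carbon.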